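From compound 1 to compound 4: adding a carbonyl

This account rests on a few compounds, and the source may have more. Where it says the series, first, only, none or still open, it means among the compounds named here.

In a functional assay on MDA-MB-231 cells (Homo sapiens) for antiproliferative activity, read by MTT assay, with a stated time of 24 h (on this read-out higher numbers stand for weaker inhibition and lower numbers for stronger inhibition), compound 1 `O=C(NNc1cccc(Cl)c1)c1cccc(NS(=O)(=O)c2cnc(O)nc2O)c1` gives 7760 nM and compound 2 `O=C(NNc1cccc(Cl)c1)c1ccccc1NS(=O)(=O)c1cnc(O)nc1O` gives 11800 nM, two values within the usual scatter of each other. For the measured compounds named here, these are the only two numbers so far.

Compound 3 `O=C(NNC(=O)c1ccccc1F)c1ccc(NS(=O)(=O)c2cnc(O)nc2O)cc1` gives > 20000 nM, which is a limit of the assay and not a number.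

Compound 4 `O=C(NNC(=O)c1cccc(NS(=O)(=O)c2cnc(O)nc2O)c1)c1cccc(Cl)c1` takes (3-chlorophenyl)carbonyl in place of 3-chlorophenyl on an amine nitrogen. Going by the values given here, no measured pair isolates this change, so the expectation rests on one indirect comparison. Compound 3 also carries a carbonyl on that amine nitrogen and stays at > 20000 nM, although it differs from compound 1 elsewhere too.

A moderate move towards weaker inhibition is therefore expected in this assay, and a result reported only as a limit remains possible. The expected step is a 1.5-fold higher number from compound 1 to compound 4 (0.19 log units; within the scatter). The estimate for compound 4 is 12000 nM, with an expected range from 5000 nM to 20000 nM.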

Compound 4, half-maximal inhibitory concentration: 3180 nM
For compound 4 the middle estimate is 3.8-fold (0.58 log units) above the measured one; measured number outside the range, below it.
By their numbers in this assay, from the lowest: compound 4; then compounds 1 and 2 (each within the scatter of the next). At a limit, above all of these: compound 3.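

In this assay, the series now has its first pair differing in one place: on an amine nitrogen whose other neighbours are: amide-type nitrogen, (3-chlorophenyl)carbonyl in place of 3-chlorophenyl gives a 2.4-fold lower number from compound 1 to compound 4 (0.39 log units; beyond the scatter). This position therefore responds to the change, and the added carbonyl goes with stronger inhibition on the core of compound 1, a reading that rests on this single pair. Compound 3 also carries a carbonyl on that nitrogen, but its entry is a limit of the assay and not a number: the limit of > 20000 nM in this assay, at which 1 of the 4 values shown sits.

From the compounds shown here alone, whether the 3-chlorophenyl ring is needed with the carbonyl remains open, as a plain acetyl or a sulfonyl on this nitrogen would test. Going by these compounds, whether the step carries over to the core of compound 2 also remains open.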